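The source may report more compounds than this note shows. Statements on the series, on what has been measured and on what is new or still open speak of the compounds shown alone.

Compound 1 `N#CC1=C(NC(=O)c2ccc([N+](=O)[O-])cc2)N(c2ccc(S(N)(=O)=O)cc2)C2=C(C(=O)CCC2)C1c1ccc(Cl)cc1Cl` is the reference point of the series. In a functional assay on Ehrlich cells (Mus musculus) for cytotoxicity, read by trypan blue exclusion, with a stated time of 2 h, tested at 25 ug/mL (a higher number here means a stronger effect of the compound at the concentration tested, a lower number a weaker effect), compound 1 gives 40%. Compound 2 `CN(C)c1ccc(/C=N/C2=C(C#N)C(c3ccc(Cl)cc3Cl)C3=C(CCCC3=O)N2c2ccc(S(N)(=O)=O)cc2)cc1` carries a different group on the double-bonded ring carbon, and in this assay compound 2 gives 30%, so that a number 10 percentage points lower from compound 1 to compound 2 (within the scatter). Compound 3 `CN(C)c1ccc(/C=C/C=N/C2=C(C#N)C(c3ccc(Cl)cc3Cl)C3=C(CCCC3=O)N2c2ccc(S(N)(=O)=O)cc2)cc1` extends that group further, and in this assay compound 3 gives 20%, with a number 10 percentage points lower from compound 2 to compound 3 (within the scatter). Compound 3 thus holds the lowest of the three numbers, but its distance from compound 2 lies within the scatter; only its distance from compound 1 is beyond it.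

Compound 4 `N#CC1=C(/N=C/c2ccc([N+](=O)[O-])cc2[N+](=O)[O-])N(c2ccc(S(N)(=O)=O)cc2)C2=C(C(=O)CCC2)C1c1ccc(Cl)cc1Cl` is the next step, with 2,4-dinitrophenyl in place of 2-(4-(dimethylamino)phenyl)ethenyl on a carbon with a double bond to nitrogen. Both measured steps changed the group at this same place and each stayed within the scatter, so the record gives no sign that this position moves the read-out strongly. The entering 2,4-dinitrophenyl brings the read-out back toward a smaller, oxygen-rich group, nearer in kind to what compound 1 carries at 40%, so a small rise is possible but not a large one. Compound 4 is therefore expected at 30%, between 15% and 50%, which means an estimated a number 10 percentage points higher from compound 3 to compound 4 (within the scatter).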

Compound 4, a percentage reported as activity, at one concentration (the size of the read-out at that concentration, not a potency): 20%
Compound 4: middle estimate off by 10 percentage points, on the high side; the measured number falls inside the stated range.
By their numbers in this assay, from the lowest: compounds 3, 4, 2 and 1 (each within the scatter of the next, the first and the last beyond it).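

At the carbon with a double bond to nitrogen, the exchange of 2-(4-(dimethylamino)phenyl)ethenyl for 2,4-dinitrophenyl in this assay gives no change at the digits printed from compound 3 to compound 4 (within the scatter) and so leaves the read-out unmoved, while the exchange of 4-(dimethylamino)phenyl for the same group gives a number 10 percentage points lower from compound 2 to compound 4 (within the scatter). The earlier steps shown here at this place compared only groups that carry a dimethylamino group, whereas compound 4 puts two nitro groups on the ring and has no dimethylamino group, so this position has now tolerated a much wider change in the group's make-up with no step beyond the scatter among compounds 2, 3 and 4. Nothing available here explains why such different groups give readings this close.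

Whether an unsubstituted phenyl, or a ring bearing a carboxylic acid or a primary amine, would also stay within the scatter of these compounds remains open. Also open is whether these groups would still read alike at other concentrations, since each compound is shown at a single concentration and a single exposure time.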